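The compounds below may be only part of what the source reports. "The series", "measured", "known", "first", "only" and "open" are said of these compounds alone.

Measured compounds:
- compound 1 `C[C@@H](O[C@@H]1CN(C(=O)[C@@H]2CCC(=O)N2C)C[C@H]1c1ccc(F)cc1)c1cc(C(F)(F)F)cc(C(F)(F)F)c1`: 0.12 nM
- compound 2 `C[C@@H](O[C@@H]1CN(C(=O)N2CCOCC2)C[C@H]1c1ccccc1)c1cc(C(F)(F)F)cc(C(F)(F)F)c1`: 0.16 nM

Compound 1 stands at the lowest of the two numbers in an assay on CHO cells for displacement of a labelled ligand from Substance-P receptor (Homo sapiens) (a higher number here means a weaker inhibitor, a lower number a stronger inhibitor), with compound 2 the nearest at a slightly higher number, a gap that lies within the scatter; the two are therefore not told apart by this assay. Compound 3 `C[C@@H](O[C@@H]1CN(C2=CC(=O)N(C)C2)C[C@H]1c1ccc(F)cc1)c1cc(C(F)(F)F)cc(C(F)(F)F)c1` has not yet been measured. It differs from compound 1 in one place: a group of 7 heavy atoms (5 carbon, 1 nitrogen, 1 oxygen; one five-membered non-aromatic ring with 1 hetero atom) in place of a group of 9 heavy atoms (6 carbon, 1 nitrogen, 2 oxygen; one five-membered non-aromatic ring with 1 hetero atom), on an amine nitrogen in a ring. Going by the values given here, both compounds so far share the ether-linked side chain and the core, and with only two such numbers there is no measured step between compounds to lean on. The group that enters keeps a five-membered non-aromatic ring with one hetero atom on the same amine nitrogen, so a small step is expected, if any, and more likely toward a slightly higher number than a lower one. Compound 3 is expected to give 0.25 nM in this assay, within 0.06 nM to 1 nM, which means a step of a 2.1-fold higher number from compound 1 to compound 3 (0.32 log units; beyond the scatter) that is estimated to stay close to the scatter.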

Compound 3, half-maximal inhibitory concentration: 0.12 nM
Beside the measured number, compound 3's estimate is 2.1-fold (0.32 log units) above it; low and high end bracket the measured number.
By their numbers in this assay, from the lowest: compounds 1, 3 and 2 (each within the scatter of the next).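

In this assay, going by these compounds alone, the step reads no change at the digits printed from compound 1 to compound 3 (within the scatter), the first comparison here between compounds that differ in one place. On this amine nitrogen in a ring, the (1-methyl-5-oxopyrrolidin-2-yl)carbonyl group can therefore give way to a group with fewer heavy atoms, fewer hydrogen-bond acceptors and no defined stereocentre, while the number stays within the scatter and remains among the low values seen so far. No measurement shown here accounts for this result.

The compounds shown leave open whether the same position would hold its number with a free amine, a carboxylic acid or a longer alkyl chain in place of this ring. Within the data shown here, they also leave open whether the single step seen on the 4-fluorophenyl-bearing core would carry over to other groups at that position.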